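Series notes: aryl substitution on the enone side chain

The source may report more compounds than this note shows. Statements on the series, on what has been measured and on what is new or still open speak of the compounds shown alone.

Among the measured compounds shown here, the two compounds measured so far share a core carrying a hydroxamic acid and an enone side chain ending in an aryl ring. Compound 1 `Cn1cc(/C=C/C(=O)c2ccccc2)cc1/C=C/C(=O)NO` gives 260 nM in an assay on isolated protein for inhibition of histone deacetylase HD1B (Zea mays); a higher number here means a weaker inhibitor, a lower number a stronger inhibitor. For the measured compounds named here, compound 2 `Cn1cc(/C=C/C(=O)c2ccc(Cl)cc2)cc1/C=C/C(=O)NO` gives 29400 nM in this assay; it stands at the highest number of the two, and the one step recorded, a 110-fold higher number from compound 1 to compound 2 (2.05 log units; beyond the scatter), is the whole of what is known about the aryl ring.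

Compound 3 `Cn1cc(/C=C/C(=O)c2ccccc2F)cc1/C=C/C(=O)NO` differs from compound 2 in that (2-fluorophenyl in place of 4-chlorophenyl on a carbonyl carbon). The step from compound 1 to compound 2 bears on this change in part: it shows that putting a chloro on the ring cost a large amount, and compound 3 takes that chloro away again. Nothing measured speaks to what the fluorine brings, since no fluorinated ring has been tested. On this basis compound 3 is expected to move back toward compound 1, with a 42-fold lower number from compound 2 to compound 3 (1.62 log units; beyond the scatter) as the estimated step, though the fluorine leaves the outcome uncertain. The estimate for compound 3 in this assay is 700 nM, within a range of 150 nM to 4000 nM.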

Compound 3, half-maximal inhibitory concentration: 3400 nM
Compound 3: the middle estimate sits 4.9-fold (0.69 log units) below what was measured; low and high end bracket the measured number.
By their numbers in this assay, from the lowest: compound 1; then compound 3; then compound 2.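

In this assay the 2-fluorophenyl ring of compound 3 does not return to the level of the plain phenyl ring, with a 13-fold higher number from compound 1 to compound 3 (1.12 log units; beyond the scatter) as the step, so the loss is not confined to the chloro of compound 2, and in these three compounds both halogen-bearing rings stand above the unsubstituted ring, with none going against this. Exchanging one substituted ring for the other gives an 8.6-fold lower number from compound 2 to compound 3 (0.94 log units; beyond the scatter) as a modest recovery, showing that the size of the loss depends on which substituted ring is present, although this change alters the halogen and its place on the ring together and cannot separate the two. Nothing at hand offers an explanation for either shift.

Open, from the compounds shown here alone, is how halogen and place divide the effect, which a fluoro at the place of the chloro in compound 2, or a chloro at the place of the fluoro in compound 3, would address. Also open, going by these compounds, is whether a ring substituent other than a halogen, such as a methoxy group or an amine, would raise the number in the same way.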